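This account rests on a few compounds, and the source may have more. Where it says the series, first, only, none or still open, it means among the compounds named here.

Compound 1 `Clc1ncc(OCC2CCCN2)cc1/C=C/c1ccncc1` gives the lowest number among three compounds measured in an assay for binding affinity to Neuronal acetylcholine receptor; alpha4/beta2 (Rattus norvegicus) (on this read-out higher numbers stand for weaker inhibition and lower numbers for stronger inhibition), at 0.015 nM. Compound 2 `CN1CCCC1COc1cnc(Cl)c(/C=C/c2ccncc2)c1` gives 0.028 nM, and the change a 1.9-fold higher number from compound 1 to compound 2 (0.27 log units; within the scatter) stays within the scatter. Compound 3 `CN1CCCC1COc1cnc(Cl)c(/C=C/c2cccnc2)c1` gives 0.088 nM; the step of a 3.1-fold higher number from compound 2 to compound 3 (0.50 log units; beyond the scatter) shows that moving the ring nitrogen cost some affinity. Compound 4 `Clc1ncc(OCC2CCCN2)cc1/C=C/c1ccccn1` carries the change (pyridin-2-yl in place of pyridin-4-yl on a double-bonded chain carbon bound to a double-bonded chain carbon). For the measured compounds named here, only that step from compound 2 to compound 3 bears on this, since it also relocates the pyridine nitrogen, and it was modest. A loss of similar size is therefore expected for compound 4, though with some uncertainty in either direction: the estimated step is a 4.0-fold higher number from compound 1 to compound 4 (0.60 log units; beyond the scatter), giving compound 4 an expected value of 0.06 nM, with a range from 0.015 nM to 0.3 nM.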

Compound 4, inhibition constant: 0.331 nM
Estimate against measurement, compound 4: 5.5-fold (0.74 log units) below; the measured number lies above the stated range.
By their numbers in this assay, from the lowest: compounds 1 and 2 (each within the scatter of the next); then compound 3; then compound 4.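

In this assay, pyridin-2-yl in place of pyridin-4-yl on a double-bonded chain carbon gives a 22-fold higher number from compound 1 to compound 4 (1.34 log units; beyond the scatter), a large step, whereas the earlier swap of pyridin-3-yl for pyridin-4-yl was only modest. At this place, then, two rings with the same atoms can give very different numbers, depending only on how the ring is joined to the chain. Nothing measured here explains the size of this loss.

Still open, as far as these compounds go, is how a plain phenyl ring, with no ring nitrogen, would compare at this place. From the compounds shown here alone, it is also open whether pyridin-2-yl would cost as much with the methyl group of compound 2 on the amine nitrogen.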